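Adding a second chloro to compound 2

A few compounds are considered here, and "the series" means these few. Any claim that something is new, unique, unknown or untested is made for them only; others in the source may bear on it.

In a functional assay on the whole organism (blood) with Rattus norvegicus as the target (a higher number here means that more compound is needed for the effect, a lower number that less compound is needed), compound 1 (`CCOC(=O)C1(CCCc2ccc(Cl)cc2)CO1`) gives 200 umol/kg, compound 2 (`CCOC(=O)C1(CCCc2cccc(Cl)c2)CO1`) gives 680 umol/kg and compound 3 (`CCOC(=O)C1(CCCc2ccccc2)CO1`) gives 1170 umol/kg. Compound 2 thus holds the second highest of the three numbers. It lies within the scatter of compound 3, while compound 1 has a clearly lower number than either.

Compound 4 (`CCOC(=O)C1(CCCc2ccc(Cl)c(Cl)c2)CO1`) differs from compound 2 by one change: chloro in place of hydrogen on an aromatic carbon. In words, this is chloro in place of hydrogen on an aromatic carbon, ortho to a chloro group and para to a large group.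

Among the measured compounds shown here, two measured steps bear on this change, and both remove a chloro, so they must be read in reverse. The first is a 5.9-fold higher number from compound 1 to compound 3 (0.77 log units; beyond the scatter). For the measured compounds named here, it concerns the chloro para to a large group, the one compound 4 gains. The second is a 1.7-fold higher number from compound 2 to compound 3 (0.24 log units; within the scatter). It concerns the chloro that compound 2 already carries. Going by the values given here, no measured compound carries two chloro groups, so it is unknown whether the first step carries over in full. A lower number is expected, with a step somewhat smaller than the first one.

The expected step is a 4.5-fold lower number from compound 2 to compound 4 (0.66 log units; beyond the scatter). For compound 4 the estimate is 150 umol/kg, with an expected range from 60 umol/kg to 400 umol/kg.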

Compound 4, dose for half-maximal effect: 330 umol/kg
Beside the measured number, compound 4's estimate is 2.2-fold (0.34 log units) below it; the range from low to high includes it.
By their numbers in this assay, from the lowest: compounds 1 and 4 (each within the scatter of the next); then compounds 2 and 3 (each within the scatter of the next).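

In this assay, chloro in place of hydrogen para to a large group and ortho to a chloro group still gives a step beyond the scatter, a 2.1-fold lower number from compound 2 to compound 4 (0.31 log units; beyond the scatter), so this position keeps some of its effect when a chloro is already present, but the size of the step depends on the core: the same change on two cores in this assay, a 5.9-fold higher number (0.77 log units; beyond the scatter) from compound 1 to compound 3 and a 2.1-fold higher number (0.31 log units; beyond the scatter) from compound 4 to compound 2, 2.8-fold (0.45 log units) apart, beyond the scatter of two such steps. The reverse reading holds for the chloro that compound 2 already carries, since adding it to the core of compound 1 gives a 1.7-fold higher number from compound 1 to compound 4 (0.22 log units; within the scatter), which is within the scatter and leaves that pair without a readable difference. The two chloro groups therefore do not add up across these four compounds, and the second change also differs between cores: the same change on two cores in this assay, a 1.7-fold higher number (0.24 log units; within the scatter) from compound 2 to compound 3 and a 1.7-fold lower number (0.22 log units; within the scatter) from compound 4 to compound 1, 2.8-fold (0.45 log units) apart, beyond the scatter of two such steps.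

The compounds shown leave open whether another group at this place, such as bromo, methoxy or trifluoromethyl, would give a step like that of chloro on the core of compound 2. Also open is whether a carboxylic acid in place of the ethyl ester, or a longer chain to the aromatic ring, would keep the same order among these compounds.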